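The compounds below may be only part of what the source reports. "The series", "measured", "known", "first", "only" and "open" are said of these compounds alone.

Three compounds sharing one core have so far been compared in an assay on Cerebral cortex for binding affinity to adenosine receptor A1 (Cavia porcellus), read by radioligand binding; on this read-out higher numbers stand for weaker inhibition and lower numbers for stronger inhibition. Compound 3 `CCCn1c(=O)n(C)c(=O)c2c1ncn2CCC#N` gives 88600 nM in this assay. Compound 2 `CCCn1c(=O)n(C)c(=O)c2c1ncn2CC#N` gives 6600 nM. Compound 1 `CCCn1c(=O)n(C)c(=O)c2c1ncn2CCC(=O)O` sits at a limit of the assay, > 200000 nM, which is a boundary rather than a number. Among the two numbers, compound 3 stands highest; its nearest neighbour is compound 2, and a 13-fold higher number from compound 2 to compound 3 (1.13 log units; beyond the scatter). Compound 4 `CCCn1c(=O)n(C)c(=O)c2c1ncn2CCO` has not yet been measured. It differs from compound 3 by hydroxy in place of cyano on a saturated chain carbon, two bonds along the chain from an aromatic nitrogen. Going by the values given here, two measured steps touch this region of the chain: an at least 2.2-fold lower number from compound 1 to compound 3 (0.35 log units; beyond the scatter), which rests on (the limit of > 200000 nM in this assay, at which 1 of the 3 values shown sits), and an at least 30-fold lower number from compound 1 to compound 2 (1.48 log units; beyond the scatter), where the chain is one carbon shorter. Cyano at this place therefore gave a lower number than carboxy, but hydroxy has no measured counterpart here, so the direction is uncertain and only a small step is expected, leaning toward a somewhat higher number. For compound 4 the expected step is a 1.1-fold higher number from compound 3 to compound 4 (0.05 log units; within the scatter). Compound 4 is estimated at 100000 nM in this assay, with a likely range from 30000 nM to 300000 nM.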

Compound 4, inhibition constant: 41400 nM
Compound 4: the middle estimate sits 2.4-fold (0.38 log units) above what was measured; low and high end bracket the measured number.
By their numbers in this assay, from the lowest: compound 2; then compound 4; then compound 3. At a limit, above all of these: compound 1.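

In this assay, going by these compounds alone, a 2.1-fold lower number from compound 3 to compound 4 (0.33 log units; beyond the scatter), so a hydroxy on the saturated chain carbon two bonds along the chain from an aromatic nitrogen gives a lower number than a cyano there, a small but real difference that the earlier compounds could not reveal. The 2-hydroxyethyl chain still does not reach the cyanomethyl chain, since a 6.3-fold higher number from compound 2 to compound 4 (0.80 log units; beyond the scatter), which leaves compound 2 with the lowest number of the set. Measured against the carboxy group, the step reads an at least 4.8-fold lower number from compound 1 to compound 4 (0.68 log units; beyond the scatter), and its size is only a bound, not an exact figure: the limit of > 200000 nM in this assay, at which 1 of the 4 values shown sits.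

The compounds shown do not tell how an amine or a methoxy at the same place would compare with hydroxy, or how a 3-hydroxypropyl chain would compare with the 2-hydroxyethyl chain. They also leave open whether a shorter chain would help hydroxy as it helps cyano, where a 13-fold higher number from compound 2 to compound 3 (1.13 log units; beyond the scatter) records the cost of the longer chain.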